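The source may report more compounds than this note shows. Statements on the series, on what has been measured and on what is new or still open speak of the compounds shown alone.

Working notes on the series.

Compound 1 `CNc1nc(NC(C)(C)C)c2sc(-c3ccc(C(F)(F)F)cc3)cc2n1` is the reference. In a physicochemical assay for solubility, in phosphate buffer, at pH 6.5 (on this read-out higher numbers stand for higher solubility and lower numbers for lower solubility), compound 1 gives < 1.6 ug/mL, which is a limit of the assay and not a number (the limit of < 1.6 ug/mL in this assay, at which 1 of the 3 values shown sits). Compound 2 `CNc1nc(NC2CC2)c2sc(-c3ccc(C(F)(F)F)cc3)cc2n1` in this assay gives < 5 ug/mL, again a limit (the limit of < 5 ug/mL in this assay, at which 1 of the 3 values shown sits). For the measured compounds named here, compound 3 `CNc1nc(N2CCC(N)CC2)c2sc(-c3ccc(C(F)(F)F)cc3)cc2n1` is the only member with a read number, 17 ug/mL in this assay. The step that the two limits leave unreadable from compound 1 to compound 2 therefore cannot be sized, whereas an at least 10-fold higher number from compound 1 to compound 3 (1.02 log units; beyond the scatter) and an at least 3.4-fold higher number from compound 2 to compound 3 (0.53 log units; beyond the scatter) are both readable rises.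

Compound 4 `CNc1nc(NC2CCOCC2)c2sc(-c3ccc(C(F)(F)F)cc3)cc2n1` differs from compound 1 by oxan-4-yl in place of tert-butyl on a nitrogen on an aromatic ring. The nearest measured steps are those from compound 1 and compound 2 into compound 3, where the entering group carried a basic amine; the oxan-4-yl group brings a ring and one hydrogen-bond acceptor but no amine, so a smaller rise than an at least 10-fold higher number from compound 1 to compound 3 (1.02 log units; beyond the scatter) is expected. The estimated step of an at least 3.1-fold higher number from compound 1 to compound 4 (0.49 log units; beyond the scatter) is a modest rise in this assay, with a real chance that compound 4 still returns only a limit. Compound 4 is expected to give about 5 ug/mL in this assay, within a range of 1.5 ug/mL to 20 ug/mL.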

Compound 4, solubility: < 5 ug/mL
Compound 4: a limit, no number; the forecaster's own chance of this, stated with the estimate: 35%; the middle value sits exactly at the limit.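

In this assay compound 4 returns a limit and not a number: the limit of < 5 ug/mL in this assay, at which 2 of the 4 values shown sit. Exchanging 4-aminopiperidin-1-yl for (oxan-4-yl)amino on the aromatic carbon gives an at least 3.4-fold lower number from compound 3 to compound 4 (0.53 log units; beyond the scatter), so among the compounds shown, compound 3 remains the only one with a read number. The steps from compound 1 and from compound 2 to compound 4 have limits at both ends and cannot be read, which leaves oxan-4-yl on this nitrogen not told apart from tert-butyl or cyclopropyl.

From the compounds shown here alone, how far compound 1, compound 2 and compound 4 each lie under their limits stays open. Also open, going by these compounds, is whether the read number of compound 3 goes with the primary amine or with attachment through the piperidine nitrogen, a question that a morpholin-4-yl or a (piperidin-4-yl)amino group on the same aromatic carbon would address.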